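From Cyclohexyloxy to (4-Methylphenyl)amino: Compound 4 Expected

The source may hold more compounds than are shown below. What is called first, only, known or untested is meant among the compounds shown, and "the series" means these compounds.

Measured so far in a functional assay on SAOS-2 cells (Homo sapiens) for antiproliferative activity, read by MTT assay, with a stated time of 72 h; on this read-out lower numbers stand for stronger inhibition and higher numbers for weaker inhibition:
Compound 1 `O=C(C1=C(O)C(=O)N(CCCn2ccnc2)C1c1ccc(Br)cc1)c1ccccc1` gives 31600 nM.
Compound 2 `CCCCOC1=C(C(=O)c2ccccc2)C(c2ccc(Br)cc2)N(CCCn2ccnc2)C1=O` gives 11600 nM.
Compound 3 `O=C(C1=C(OC2CCCCC2)C(=O)N(CCCn2ccnc2)C1c1ccc(Br)cc1)c1ccccc1` gives 29700 nM.

Among these three numbers compound 3 holds the second highest; its nearest neighbour is compound 1, and the two lie within the scatter of each other, while compound 2 is the furthest away. The three measured compounds differ only in what sits on the oxygen attached to the double-bonded ring carbon of the shared core: hydrogen, butyl or cyclohexyl. The two steps beyond the scatter are a 2.7-fold lower number from compound 1 to compound 2 (0.44 log units; beyond the scatter) and a 2.6-fold higher number from compound 2 to compound 3 (0.41 log units; beyond the scatter), whereas a 1.1-fold lower number from compound 1 to compound 3 (0.03 log units; within the scatter) stays within it.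

Compound 4 `Cc1ccc(NC2=C(C(=O)c3ccccc3)C(c3ccc(Br)cc3)N(CCCn3ccnc3)C2=O)cc1` changes that same position in a different way: (4-methylphenyl)amino in place of cyclohexyloxy on a double-bonded ring carbon. The oxygen leaves together with its cyclohexyl, and a nitrogen carrying a hydrogen and a 4-methylphenyl group takes its place. For the measured compounds named here, none of the measured steps swaps the linking atom, so they bear on the expectation only by showing how narrow the range of this series is: the whole set spans no more than the step described by a 2.7-fold lower number from compound 1 to compound 2 (0.44 log units; beyond the scatter). Going by the values given here, with no direct precedent, the step is expected to be a 1.5-fold lower number from compound 3 to compound 4 (0.17 log units; within the scatter), that is, nothing beyond the scatter, with a wide range to allow for the untested change of linking atom. Compound 4 is therefore estimated at 20000 nM in this assay, between 6000 nM and 60000 nM.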

Compound 4, half-maximal inhibitory concentration: 31900 nM
Beside the measured number, compound 4's estimate is 1.6-fold (0.20 log units) below it; the range from low to high includes it.
By their numbers in this assay, from the lowest: compound 2; then compounds 3, 1 and 4 (each within the scatter of the next).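

In this assay, exchanging the cyclohexyloxy group for (4-methylphenyl)amino gives a 1.1-fold higher number from compound 3 to compound 4 (0.03 log units; within the scatter), and exchanging the hydroxy group of compound 1 for the same group gives a 1.0-fold higher number from compound 1 to compound 4 (0.00 log units; within the scatter). For the compounds shown here, this position on the double-bonded ring carbon therefore accepts a nitrogen link and an aromatic ring with no shift beyond the scatter, something the earlier compounds, all linked through oxygen, could not show. The butoxy group remains the only one that stands apart, with a 2.8-fold higher number from compound 2 to compound 4 (0.44 log units; beyond the scatter), so compound 2 keeps the lowest number of the four, though the gap is modest, and nothing shown here gives a reason for these results.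

From the compounds shown here alone, in compound 4 the linking atom and the group it carries change together, so the effect of each alone stays unknown: a 4-methylphenoxy group would keep the aromatic ring on oxygen, while a butylamino group would put the chain of compound 2 on nitrogen. Going by these compounds, it also remains open whether the lower number of compound 2 belongs to straight chains in general, which a propoxy or hexyloxy group would help to test.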